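The compounds below may be only part of what the source reports. "The series", "measured", "known", "first", "only" and "open" are said of these compounds alone.

Measured compounds in an assay for inhibition of mitogen-activated protein kinase kinase kinase 14 (Homo sapiens), read by luminescence and ADP-Glo, with a stated time of 120 min, in the presence of a further agent that is not named here; a higher number here means a weaker inhibitor, a lower number a stronger inhibitor:
compound 1 `CC(O)(C#Cc1cccc(Nc2ncnc3[nH]ccc23)c1)c1nccs1` gives 1640 nM;
compound 2 `CC(O)(C#Cc1ccc(N2CCCC2)c(Nc2ncnc3[nH]ccc23)c1)c1nccs1` gives 107 nM;
compound 3 `C[C@@H]1CN(c2ccc(C#CC(C)(O)c3nccs3)cc2Nc2ncnc3[nH]ccc23)CCN1` gives 210 nM.

Compound 3 holds the second highest number of the three; its nearest neighbour is compound 2, a gap within the scatter, and its furthest is compound 1, a gap beyond the scatter. The measured steps of a 15-fold lower number from compound 1 to compound 2 (1.19 log units; beyond the scatter) and a 7.8-fold lower number from compound 1 to compound 3 (0.89 log units; beyond the scatter), both beyond the scatter, and a 2.0-fold higher number from compound 2 to compound 3 (0.29 log units; within the scatter), within it, all concern the group placed on the aromatic carbon.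

Compound 4 `C[C@H]1CN(c2ccc(C#CC(C)(O)c3nccs3)cc2Nc2ncnc3[nH]ccc23)CCN1` differs from compound 3 only as the two compounds have the same atoms and bonds; at least one stereo element is drawn with a configuration in one of them and without one in the other: 1 of 2 stereo elements differ; a stereocentre at a saturated ring carbon is drawn R in compound 3 and S in compound 4. Going by the values given here, no measured step changes a stereocentre, so none bears directly on this step; no change beyond the scatter is expected in this assay, with a wide range to allow for it. For compound 4 the estimated value is 230 nM (range 80 nM to 700 nM), the expected step being a 1.1-fold higher number from compound 3 to compound 4 (0.04 log units; within the scatter).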

Compound 4, half-maximal inhibitory concentration: 69.2 nM
Compound 4: middle estimate off by 3.3-fold (0.52 log units), on the high side; the measured number lies below the stated range.
By their numbers in this assay, from the lowest: compounds 4, 2 and 3 (each within the scatter of the next, the first and the last beyond it); then compound 1.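

Configuration at the saturated ring carbon of the 3-methylpiperazin-1-yl group counts here: drawing it S gives a 3.0-fold lower number from compound 3 to compound 4 (0.48 log units; beyond the scatter) and no earlier step touched a stereocentre. With the S form, replacing hydrogen gives a 24-fold lower number from compound 1 to compound 4 (1.37 log units; beyond the scatter) and replacing pyrrolidin-1-yl gives a 1.5-fold lower number from compound 2 to compound 4 (0.19 log units; within the scatter) so the S form and pyrrolidin-1-yl cannot be told apart. The step from compound 3 to compound 4 traces to a single structural difference: the fact that one of compounds 3 and 4 is drawn with a defined configuration and the other without, at the place where they differ

Open, on these data alone, is whether the same preference holds with an ethyl or hydroxymethyl group in place of the methyl. Also open, as far as these compounds go, is how a morpholine would compare with the piperazine.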